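Compound 4: a longer saturated chain on the shared core

The compounds below may be only part of what the source reports. "The series", "measured", "known", "first", "only" and "open" are said of these compounds alone.

Compound 3 `CCCCCCCCSC(=O)NC(=O)Oc1c(C(C)C)cccc1C(C)C` stands in an assay on microsomes from intestine for inhibition of acyl-CoA:cholesterol acyltransferase (Oryctolagus cuniculus) (a lower number here means a stronger inhibitor, a higher number a weaker inhibitor), at 160 nM. Compound 1 `CC(C)c1cccc(C(C)C)c1OC(=O)NC(=O)SCc1ccc(Cl)cc1` gives 160 nM, and the two share the lowest number of the three, since no change at the digits printed from compound 1 to compound 3 (within the scatter). Compound 2 `CC(C)c1cccc(C(C)C)c1OC(=O)NC(=O)SCCc1ccccc1` gives 880 nM, and the gap a 5.5-fold lower number from compound 2 to compound 3 (0.74 log units; beyond the scatter) is modest but beyond the scatter. Compound 4 `CCCCCCCCCCSC(=O)NC(=O)Oc1c(C(C)C)cccc1C(C)C` differs from compound 3 only by ethyl in place of hydrogen on a saturated chain carbon, eight bonds along the chain from a sulfur. For the measured compounds named here, two measured steps bear on this change: a 5.5-fold lower number from compound 2 to compound 3 (0.74 log units; beyond the scatter), where hexyl replaced phenyl and the number fell, and no change at the digits printed from compound 1 to compound 3 (within the scatter), where heptyl replaced 4-chlorophenyl without any change. Extending an already long chain by a further ethyl is therefore expected to move the number little, a 1.2-fold lower number from compound 3 to compound 4 (0.09 log units; within the scatter). Compound 4 is estimated at 130 nM, within 60 nM to 300 nM.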

Compound 4, half-maximal inhibitory concentration: 130 nM
Estimate against measurement, compound 4: no gap at the digits printed; the measured number falls inside the stated range.
By their numbers in this assay, from the lowest: compounds 4, 1 and 3 (each within the scatter of the next); then compound 2.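

Adding ethyl in place of hydrogen, eight bonds along the chain from a sulfur, gives (a 1.2-fold lower number from compound 3 to compound 4 (0.09 log units; within the scatter)), so this longer chain holds the number in this assay level. The nonyl end also matches the 4-chlorophenyl end within the scatter (a 1.2-fold lower number from compound 1 to compound 4 (0.09 log units; within the scatter)), while the octyl-for-phenyl step stays beyond it (a 6.8-fold lower number from compound 2 to compound 4 (0.83 log units; beyond the scatter)). No evidence here accounts for this tolerance of added chain length. Open, on these data alone, is where the number would go with a still longer chain, or with an amine or a carboxylic acid at the chain end.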